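Lengthening the Alkyl Chain on a Weak Aortic Relaxant

A few compounds are considered here, and "the series" means these few. Any claim that something is new, unique, unknown or untested is made for them only; others in the source may bear on it.

Measured compounds:
Compound 1, `OCc1ccc(-c2nn(Cc3cncnc3)c3ccccc23)o1`, 3200 nM
Compound 2, `CCc1cnc(-c2nn(Cc3ccccc3F)c3ncccc23)nc1N`, 272000 nM

In a functional assay (aorta) with Oryctolagus cuniculus as the target (a lower number here means a stronger inhibitor, a higher number a weaker inhibitor), compound 2 gives the higher of the two numbers, and compound 1 gives the lower. Compound 3, `CCCCCc1cnc(-c2nn(Cc3ccccc3F)c3ncccc23)nc1N`, differs from compound 2 in one place: propyl in place of hydrogen on a saturated chain carbon, two bonds along the chain from an aromatic carbon. Among the compounds with values here, no measured pair shows this kind of change, so its effect is unknown. The change from compound 2 to compound 3 is expected to be small, a 1.8-fold lower number from compound 2 to compound 3 (0.26 log units; within the scatter), with the direction uncertain. Compound 3 is therefore estimated at 150000 nM, within a range from 40000 nM to 600000 nM.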

Compound 3, half-maximal inhibitory concentration: 200000 nM
For compound 3 the middle estimate is 1.3-fold (0.12 log units) below the measured one; the measured number falls inside the stated range.
By their numbers in this assay, from the lowest: compound 1; then compounds 3 and 2 (each within the scatter of the next).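

In this assay, within the data shown here, the first reading at this position comes from putting propyl in place of hydrogen on a saturated chain carbon (a 1.4-fold lower number from compound 2 to compound 3 (0.13 log units; within the scatter)). Extending ethyl to pentyl here therefore leaves the number within the scatter, and the position accepts this added chain without a change that can be read. No measurement given bears on why this is so.

As far as these compounds go, whether a hydroxyl group or an amine at the end of the chain, or a phenyl ring in place of the propyl, would shift the number remains open.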